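The source may report more compounds than this note shows. Statements on the series, on what has been measured and on what is new or still open speak of the compounds shown alone.

Among the measured compounds shown here, compound 2 `Cc1ccccc1C(=O)Nc1ccc(S(=O)(=O)NC2CCN(C(=O)C3CNC3)CC2)c2ccccc12` gives 1.5 nM in an assay on L1.2 cells for binding affinity to C-C chemokine receptor type 8 (Homo sapiens) (a lower number here means a stronger inhibitor, a higher number a weaker inhibitor), the lowest of the two numbers so far; compound 1 `Cc1ccccc1C(=O)Nc1ccc(S(=O)(=O)NC2CCN(C(=O)CCN)CC2)c2ccccc12` gives 11.3 nM in this assay. For the measured compounds named here, the one measured step, a 7.5-fold lower number from compound 1 to compound 2 (0.88 log units; beyond the scatter), exchanged one group bearing a hydrogen-bond donor for another such group. Compound 3 `Cc1ccccc1C(=O)Nc1ccc(S(=O)(=O)NC2CCN(C(=O)N3CCCCC3)CC2)c2ccccc12` differs from compound 2 by piperidin-1-yl in place of azetidin-3-yl on a carbonyl carbon, which removes the donor and acceptor counted there. Going by the values given here, no measured step covers such a loss, so only the direction is guessed: affinity is expected to weaken, by a step of a 10-fold higher number from compound 2 to compound 3 (1.00 log units; beyond the scatter). Compound 3 is estimated at 15 nM, within 3 nM to 80 nM.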

Compound 3, inhibition constant: 4.2 nM
Compound 3: middle estimate off by 3.6-fold (0.55 log units), on the high side, and the stated range covers the measured number.
By their numbers in this assay, from the lowest: compound 2; then compound 3; then compound 1.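

Replacing azetidin-3-yl on this carbonyl carbon with piperidin-1-yl, which counts 0 hydrogen-bond donors, gives a 2.8-fold higher number from compound 2 to compound 3 (0.45 log units; beyond the scatter) in this assay and so weakens affinity only modestly. A donor at this place is therefore not required for nanomolar binding. Against 2-aminoethyl, the same group gives a 2.7-fold lower number from compound 1 to compound 3 (0.43 log units; beyond the scatter) and so the donor count alone does not order the three compounds; nothing available explains this order.

Open, on these data alone, is how a morpholine ring or an acyclic dialkylamine on this carbonyl carbon would compare. A carboxylic acid in this place also remains untested in the compounds shown.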